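The compounds below may be only part of what the source reports. "The series", "measured", "known", "first", "only" and "open" are said of these compounds alone.

Compound 2 `Cc1ccc2nc(Nn3c(-c4ccc([N+](=O)[O-])cc4)nnc3-c3cccnc3)sc2c1` gives the highest number of the three measured in an ADME assay on MT4 cells (Homo sapiens) for cytotoxicity, read by MTT assay, with a stated time of 5 days (a lower number here means that less compound is tolerated, a higher number that more compound is tolerated), at 64.4 ug/mL. Compound 1 `O=[N+]([O-])c1ccc(-c2nnc(-c3cccnc3)n2Nc2nc3ccc(Br)cc3s2)cc1` gives 13.2 ug/mL in this assay, and compound 3 `Cc1cccc2sc(Nn3c(-c4ccc([N+](=O)[O-])cc4)nnc3-c3cccnc3)nc12` gives 13.5 ug/mL. The two steps leading to compound 2 are of similar size: a 4.9-fold higher number from compound 1 to compound 2 (0.69 log units; beyond the scatter), and a 4.8-fold lower number from compound 2 to compound 3 (0.68 log units; beyond the scatter). Between compound 1 and compound 3 the numbers are the same within the scatter, a 1.0-fold higher number from compound 1 to compound 3 (0.01 log units; within the scatter).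

Compound 4 `Cc1ccc2nc(Nn3c(-c4ccc(Cl)cc4)nnc3-c3cccnc3)sc2c1` differs from compound 2 in one place: chloro in place of nitro on an aromatic carbon. Within the data shown here, none of the three measured steps touches this part of the molecule; all of them concern the group on the nitrogen on the aromatic ring, so no measured step bears directly on the exchange of nitro for chloro. The measured steps show that a single change can move this assay by a modest amount, roughly the size of the step from compound 1 to compound 2, or leave it within the scatter.

Among the measured compounds shown here, with no direct precedent, compound 4 is expected to sit near compound 2, with a wide range, as a 1.6-fold lower number from compound 2 to compound 4 (0.21 log units; within the scatter). The estimate for compound 4 in this assay is 40 ug/mL, expected to lie between 12 ug/mL and 110 ug/mL.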

Compound 4, half-maximal cytotoxic concentration: 75.5 ug/mL
For compound 4 the middle estimate is 1.9-fold (0.28 log units) below the measured one; the range from low to high includes it.
By their numbers in this assay, from the lowest: compounds 1 and 3 (each within the scatter of the next); then compounds 2 and 4 (each within the scatter of the next).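

In this assay, the exchange of nitro for chloro on the aromatic carbon para to a large group gives a 1.2-fold higher number from compound 2 to compound 4 (0.07 log units; within the scatter), so this is a single change that leaves the number within the scatter. It is also the first measured change outside the group on the nitrogen, and it contrasts with the step in that group, a 4.9-fold higher number from compound 1 to compound 2 (0.69 log units; beyond the scatter), which lies beyond the scatter. With that group kept as in compound 2, the nitro is therefore not needed for the high number in this assay, but nothing in the data explains why 4-nitrophenyl and 4-chlorophenyl read alike.

As far as these compounds go, this rests on one pair, so it remains open whether other groups at this place, such as an amine or a carboxylic acid, would also leave the number within the scatter. From the compounds shown here alone, it is also open whether chloro in place of nitro would read the same alongside the groups on the nitrogen of compound 1 and compound 3, whose numbers are lower.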